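Ether substituent exchanges on a shared acid core

The compounds below may be only part of what the source reports. "The series", "measured", "known", "first", "only" and "open" are said of these compounds alone.

Compound 1 `Cc1cc(OCc2cccc3nccn23)cc(C)c1-c1cccc(COc2ccc3c(c2)OC[C@H]3CC(=O)O)c1` gives 17 nM in a functional assay on CHO cells for agonist activity at Free fatty acid receptor 1 (Homo sapiens), read by FLIPR and calcium flux, with a stated time of 90 s, in the presence of a further agent that is not named here; on this read-out lower numbers stand for an effect already at smaller amounts and higher numbers for an effect only at larger amounts of compound.
Compound 2 `Cc1cc(OCCCN2CCCC2=O)cc(C)c1-c1cccc(COc2ccc3c(c2)OC[C@H]3CC(=O)O)c1` gives 17 nM in this assay.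
Compound 3 `Cc1nc(C)c(COc2cc(C)c(-c3cccc(COc4ccc5c(c4)OC[C@H]5CC(=O)O)c3)c(C)c2)s1` gives 18 nM in this assay.

Compound 3 carries the highest of the three numbers, yet both gaps to it are within the scatter: a 1.1-fold higher number from compound 1 to compound 3 (0.02 log units; within the scatter) and a 1.1-fold higher number from compound 2 to compound 3 (0.02 log units; within the scatter). The remaining step, no change at the digits printed from compound 1 to compound 2 (within the scatter), is equally flat. The three compounds share one core and differ only in the group on the saturated chain carbon bound to the oxygen on the aromatic ring; three unlike groups in that place give numbers that cannot be told apart.

Compound 4 `CCS(=O)(=O)CCOc1cc(C)c(-c2cccc(COc3ccc4c(c3)OC[C@H]4CC(=O)O)c2)c(C)c1` makes the same kind of exchange once more: (ethylsulfonyl)methyl in place of 2,4-dimethyl-1,3-thiazol-5-yl on a saturated chain carbon bound to an oxygen on an aromatic ring. All three measured steps bear on it, since each replaced the group at that same place, and none moved the number beyond the scatter. The expected step is therefore no change at the digits printed from compound 3 to compound 4 (within the scatter), with no direction beyond the scatter. Compound 4 is estimated at 18 nM in this assay, with a range of 7 nM to 45 nM.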

Compound 4, half-maximal effective concentration in the Free fatty acid receptor 1 assay: 14 nM
For compound 4 the middle estimate is 1.3-fold (0.11 log units) above the measured one, within the range that was stated.
By their numbers in the Free fatty acid receptor 1 assay, from the lowest: compounds 4, 1, 2 and 3 (each within the scatter of the next).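

Going by these compounds alone, compound 4 brings the first group at this place with no ring, (ethylsulfonyl)methyl, and in the Free fatty acid receptor 1 assay the number stays level with all three ring-bearing compounds: a 1.3-fold lower number from compound 3 to compound 4 (0.11 log units; within the scatter), a 1.2-fold lower number from compound 2 to compound 4 (0.08 log units; within the scatter) and a 1.2-fold lower number from compound 1 to compound 4 (0.08 log units; within the scatter). A ring in the group on the saturated chain carbon bound to an oxygen on an aromatic ring is therefore not needed to hold the number among these four compounds. The flat result also hides a real difference between compound 3 and compound 4, which a physicochemical assay for lipophilicity, read by HPLC, at pH 7.4 (a lower number here means a more polar compound, a higher number a more lipophilic compound), separates, with compound 4 the more polar: the measured distribution coefficient of compound 3, 4.27, and of compound 4, 2.73, a number 1.54 log units lower (beyond the scatter) In the physicochemical assay compound 3 gives 4.27 and compound 4 gives 2.73.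

Open, on these data alone, is whether an amine or a carboxylic acid at this place would leave the number in the Free fatty acid receptor 1 assay equally flat. Also open, as far as these compounds go, is how a longer chain between the aromatic oxygen and the ethylsulfonyl group would read in either assay.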